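The compounds below may be only part of what the source reports. "The series", "measured", "known", "first", "only" and "open" are said of these compounds alone.

Measured so far in a functional assay on WM 266-4 cells (Homo sapiens) for antiproliferative activity, read by MTT assay, with a stated time of 24 h; on this read-out lower numbers stand for stronger inhibition of growth and higher numbers for weaker inhibition of growth
Compound 1 `Clc1ccc(C2CC(c3ccc4c(c3)OCCO4)=NN2c2ccccc2)cc1` gives 38600 nM
Compound 2 `Clc1cccc(C2CC(c3ccc4c(c3)OCCO4)=NN2c2ccccc2)c1` gives 1750 nM

Compound 2 has the lower of the two numbers, so it is the stronger growth inhibitor of this pair. The next structure, compound 3 `c1ccc(N2N=C(c3ccc4c(c3)OCCO4)CC2c2cccc3ccccc23)cc1`, keeps the shared core and has naphthalen-1-yl in place of 3-chlorophenyl on a saturated ring carbon. Within the data shown here, one measured step bears on this same carbon, a large one beyond the scatter (a 22-fold lower number from compound 1 to compound 2 (1.34 log units; beyond the scatter)). Among the measured compounds shown here, it shows that this assay can respond strongly to a change here, yet it involves only two chlorophenyl groups and says nothing direct about naphthalen-1-yl. For the measured compounds named here, compound 2, at 1750 nM, is the better of only two values, so a moderate rise is expected, smaller than that measured step. The estimated change is (a 2.6-fold higher number from compound 2 to compound 3 (0.41 log units; beyond the scatter)) and remains uncertain. For compound 3 the estimated value is 4500 nM within an expected range of 700 nM to 25000 nM.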

Compound 3, concentration for 50% growth inhibition: > 100000 nM
Compound 3: no number, only a limit; the forecaster's own chance of this, stated with the estimate: 5%; at least 22-fold (1.34 log units) between middle value and limit.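

For compound 3, this assay gives a limit rather than a number: the limit of > 100000 nM in this assay, at which 1 of the 3 values shown sits.

Even so, the limit can be compared with the two chlorophenyl compounds, giving an at least 57-fold higher number from compound 2 to compound 3 (1.75 log units; beyond the scatter) and an at least 2.5-fold higher number from compound 1 to compound 3 (0.41 log units; beyond the scatter). Among these compounds, the earlier compounds showed only that moving the chlorine changes the read-out; this result shows that replacing the whole chlorophenyl with naphthalen-1-yl on the saturated ring carbon weakens growth inhibition further, past both chlorophenyl compounds.

The compounds shown leave open how far past the limit compound 3 lies, so the full size of these steps remains unknown. They also leave open what an unsubstituted phenyl, naphthalen-2-yl or a phenyl carrying an amine or a carboxylic acid would give on this carbon.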